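This account rests on a few compounds, and the source may have more. Where it says the series, first, only, none or still open, it means among the compounds named here.

Compound 1 `O=C(Nc1cccc(-c2nc3ccccc3s2)c1)c1cnccc1Cl` gives 320 nM in a physicochemical assay for solubility, in phosphate buffer, measured as kinetic solubility, with a stated time of 18 h, at pH 7.4; a higher number here means a more soluble compound, a lower number a less soluble compound. Compound 2 `O=C(Nc1cccc(-c2nc3ccccc3s2)c1)c1cccnc1Cl` gives 520 nM, and compound 3 `O=C(Nc1cccc(-c2nc3ccccc3s2)c1)c1ccncc1Cl` gives 320 nM in this assay. Compound 1 stands level with compound 3, the two together the lowest of the three numbers; the step of a 1.6-fold higher number from compound 1 to compound 2 (0.21 log units; within the scatter) and the step of no change at the digits printed from compound 1 to compound 3 (within the scatter) are both within the scatter, as is a 1.6-fold lower number from compound 2 to compound 3 (0.21 log units; within the scatter). Compound 4 `O=C(Nc1ccc(F)c(-c2nc3ccccc3s2)c1)c1cnccc1Cl` differs from compound 1 by fluoro in place of hydrogen on an aromatic carbon. For the measured compounds named here, no measured step touches this position: the three steps all exchange the chloropyridinyl group on the carbonyl carbon, and none moves the number beyond the scatter. Compound 4 is therefore expected to show a step of a 1.1-fold lower number from compound 1 to compound 4 (0.06 log units; within the scatter) no larger than the scatter. The estimate for compound 4 is 280 nM, between 110 nM and 700 nM.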

Compound 4, solubility: 80 nM
Compound 4: the middle estimate sits 3.5-fold (0.54 log units) above what was measured; the measured number lies below the stated range.
By their numbers in this assay, from the lowest: compound 4; then compounds 1, 3 and 2 (each within the scatter of the next).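

In this assay, fluoro in place of hydrogen on an aromatic carbon, ortho to a group of 9 heavy atoms and para to a large group, gives a 4.0-fold lower number from compound 1 to compound 4 (0.60 log units; beyond the scatter). This is the only step shown at this position, and the only one beyond the scatter: a single fluorine moves the number further than any exchange of the chloropyridinyl group. Nothing at hand explains the drop. On these data alone, whether chloro, methyl or an amine at this position would give a similar step remains open, as does whether fluoro has the same effect with the 2-chloropyridin-3-yl group of compound 2 on the carbonyl carbon.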